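The source may report more compounds than this note shows. Statements on the series, on what has been measured and on what is new or still open speak of the compounds shown alone.

Measured compounds:
compound 1 `COc1cc(Cl)cc(-c2nn(-c3cccc(NC(=O)c4ccc(Cl)c(Cl)c4)c3)cc2-c2ccncc2)c1`, giving 84.2% in a functional assay on UACC-257 cells (Homo sapiens) for inhibition, read by sulforhodamine B assay, with a stated time of 48 h, tested at 10 uM; on this read-out higher numbers stand for a weaker effect at the one concentration tested and lower numbers for a stronger effect
compound 2 `O=C(Nc1cccc(-n2cc(-c3ccncc3)c(-c3cc(O)cc(Cl)c3)n2)c1)Nc1ccc(Cl)c(C(F)(F)F)c1`, giving -40% in this assay

Of these two numbers, compound 2 stands lowest, and compound 1 lies far above it, beyond the usual scatter. Compound 3 `COc1cc(Cl)cc(-c2nn(-c3cccc(NC(=O)Nc4ccc(Cl)c(C(F)(F)F)c4)c3)cc2-c2ccncc2)c1` differs from compound 2 in one place: methyl in place of hydrogen on an oxygen on an aromatic ring. Among the measured compounds shown here, no measured pair shows this change on its own, so its effect is unknown. The change is small, so the step is expected to be modest, though upward, toward a weaker effect, estimated as a number 50 percentage points higher from compound 2 to compound 3 (beyond the scatter). Compound 3 is therefore estimated at 10%, within a range from -35% to 70%.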

Compound 3, a percentage reported as activity, at one concentration (the size of the read-out at that concentration, not a potency): -25.9%
Compound 3: the middle estimate sits 35.9 percentage points above what was measured, and the stated range covers the measured number.
By their numbers in this assay, from the lowest: compound 2; then compound 3; then compound 1.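

Replacing hydrogen with methyl on the oxygen, which turns 3-chloro-5-hydroxyphenyl into 3-chloro-5-methoxyphenyl, gives a number 14.1 percentage points higher from compound 2 to compound 3 (beyond the scatter) in this assay and leaves both compounds with negative values, so a free hydroxy is not needed for a strong effect. Placing (4-chloro-3-(trifluoromethyl)phenyl)amino instead of 3,4-dichlorophenyl on the carbonyl carbon gives a number 110.1 percentage points lower from compound 1 to compound 3 (beyond the scatter) and is by far the larger step. No measurement here explains either step. From the compounds shown here alone, it remains open how an amine in place of the hydroxy, or a longer chain such as ethyl on that oxygen, would compare.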